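Swapping the amide aryl group on a quinazoline-type thiazole amide

The source may hold more compounds than are shown below. What is called first, only, known or untested is meant among the compounds shown, and "the series" means these compounds.

Measured compounds:
Compound 1 `COc1cc2c(Nc3nc4ccc(C(=O)Nc5c(C)cc(C)cc5C)cc4s3)ncnc2cc1OCCCN1CCC(C)CC1` gives 5600 nM in a functional assay on U-937 cells (Homo sapiens) for cytotoxicity, read by WST assay, with a stated time of 72 h; a lower number here means a stronger inhibitor, a higher number a weaker inhibitor.
Compound 2 `COc1cc2c(Nc3nc4ccc(C(=O)Nc5c(C)cccc5C)cc4s3)ncnc2cc1OCCCN1CCCCC1` gives 14700 nM in this assay.
Compound 3 `COc1cc2c(Nc3nc4ccc(C(=O)Nc5c(C)cc(C)cc5C)cc4s3)ncnc2cc1OCCCN1CCCCC1C` gives 3600 nM in this assay.

Among these three numbers compound 1 stands second highest. Going by the values given here, its closest neighbour is compound 3, reached by the only one-place step on hand: a 1.6-fold lower number from compound 1 to compound 3 (0.19 log units; within the scatter). Compound 2 differs from compound 1 in more than one place, so its higher number cannot be tied to a single change.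

Compound 4 `COc1cc2c(Nc3nc4ccc(C(=O)Nc5c(C)cccc5Cl)cc4s3)ncnc2cc1OCCCN1CCC(C)CC1` has not yet been measured. Relative to compound 1 the change is 2-chloro-6-methylphenyl in place of 2,4,6-trimethylphenyl on an amide-type nitrogen. Among the compounds with values here, no measured step touches this part of the molecule; the one step available concerns the saturated chain end and stayed within the scatter. The amide aryl group is therefore an unexplored place, and the expectation is correspondingly uncertain. Within the data shown here, with no direct precedent, a modest move toward a higher number is expected, roughly a 1.4-fold higher number from compound 1 to compound 4 (0.15 log units; within the scatter), though a result within the scatter of compound 1 would not surprise. Compound 4 is expected to give about 8000 nM, within a range of 2500 nM to 25000 nM.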

Compound 4, half-maximal inhibitory concentration: 9200 nM
Beside the measured number, compound 4's estimate is 1.2-fold (0.06 log units) below it; the range from low to high includes it.
By their numbers in this assay, from the lowest: compounds 3, 1, 4 and 2 (each within the scatter of the next, the first and the last beyond it).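

Going by these compounds alone, the amide aryl group, which no earlier step touched, can now be read: in this assay, 2-chloro-6-methylphenyl in place of 2,4,6-trimethylphenyl on the amide-type nitrogen gives a 1.6-fold higher number from compound 1 to compound 4 (0.22 log units; within the scatter) as the result of this single exchange. So the two aryl groups cannot be told apart here, even though one carries a chlorine and the other is all carbon. No measured evidence is available to explain this result.

As far as these compounds go, whether a plain phenyl, or a ring carrying an amine or a carboxylic acid, would move the number beyond the scatter at this place stays open. Also open, from the compounds shown here alone, is whether the same aryl exchange would behave alike with the 2-methylpiperidin-1-yl end of compound 3.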